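The compounds below may be only part of what the source reports. "The series", "measured", "known", "first", "only" and "open" are said of these compounds alone.

Measured so far:
compound 1 `O=C(CSc1nnc(-c2ccncc2)o1)N/N=C/c1ccccc1`; in a functional assay on SW 1116 cells (Homo sapiens) for cytotoxicity, read by MTT assay, with a stated time of 48 h (on this read-out lower numbers stand for stronger inhibition and higher numbers for weaker inhibition), compound 1 gives 16700 nM
compound 2 `O=C(CSc1nnc(-c2ccncc2)o1)N/N=C/c1ccc([N+](=O)[O-])cc1`; compound 2 gives 25800 nM
compound 3 `COc1cccc(/C=N/NC(=O)CSc2nnc(-c3ccncc3)o2)c1`; compound 3 gives 16500 nM

Compound 3 holds the lowest of the three numbers, yet the steps of a 1.0-fold lower number from compound 1 to compound 3 (0.01 log units; within the scatter) and a 1.6-fold lower number from compound 2 to compound 3 (0.19 log units; within the scatter) both stay within the scatter, so no order among the three can be read from these values.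

Compound 4 `O=C(CSc1nnc(-c2ccncc2)o1)N/N=C/c1cc(Cl)ccc1O` differs from compound 3 in one place: 5-chloro-2-hydroxyphenyl in place of 3-methoxyphenyl on a carbon with a double bond to nitrogen. For the measured compounds named here, no measured step changes the aryl group in this way. Going by the values given here, the only comparisons that bear on it are the substituent changes on the same ring, a 1.5-fold higher number from compound 1 to compound 2 (0.19 log units; within the scatter), a 1.0-fold lower number from compound 1 to compound 3 (0.01 log units; within the scatter) and a 1.6-fold lower number from compound 2 to compound 3 (0.19 log units; within the scatter), each of which stayed within the scatter. On that basis the step from compound 3 to compound 4 is expected to be a 1.0-fold higher number from compound 3 to compound 4 (0.01 log units; within the scatter), with no shift beyond the scatter in this assay in either direction. Compound 4 is accordingly expected to give about 17000 nM, with a range from 7000 nM to 42000 nM.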

Compound 4, half-maximal inhibitory concentration: 5240 nM
Estimate against measurement, compound 4: 3.2-fold (0.51 log units) above; measured number outside the range, below it.
By their numbers in this assay, from the lowest: compound 4; then compounds 3, 1 and 2 (each within the scatter of the next).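

In this assay the aryl group on a carbon with a double bond to nitrogen can move the number beyond the scatter: a 3.1-fold lower number from compound 3 to compound 4 (0.50 log units; beyond the scatter) and a 3.2-fold lower number from compound 1 to compound 4 (0.50 log units; beyond the scatter) and a 4.9-fold lower number from compound 2 to compound 4 (0.69 log units; beyond the scatter) are all modest steps, yet each is beyond it. Nitro and methoxy on the same ring gave no such separation among compounds 1, 2 and 3, so 5-chloro-2-hydroxyphenyl is the only group shown here that stands apart, and compound 4 is the most potent of the four. Against 3-methoxyphenyl, the entering group carries a hydrogen-bond donor and a chlorine, and both arrive in a single step.

Which part of the entering group goes with the shift stays open: a ring with only the chlorine or only the hydroxyl, or an amine in place of the hydroxyl, would separate them. Nothing available here accounts for the shift.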